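The compounds below may be only part of what the source reports. "The series", "measured", "known", "first", "only" and "open" are said of these compounds alone.

Measured in an ADME assay on HeLa cells (Homo sapiens) for cytotoxicity, read by resazurin assay, with a stated time of 65 h; on this read-out higher numbers stand for an effect only at larger amounts of compound and lower numbers for an effect already at smaller amounts:
- Compound 1 `O=C(Nc1ccccc1)c1ccc([N+](=O)[O-])o1`: > 20000 nM (a limit)
- Compound 2 `O=C(Nc1ccc(C(F)(F)F)cc1)c1ccc([N+](=O)[O-])o1`: > 20000 nM (a limit)
- Compound 3 `C=CCOc1ccc(NC(=O)c2ccc([N+](=O)[O-])o2)cc1C(F)(F)F`: > 20000 nM (a limit)

Compound 3 has no number on this read-out, only the limit > 20000 nM of the assay. The same holds across the series (the limit of > 20000 nM in this assay, at which 3 of the 3 values shown sit).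

Compound 4 `C=CCOc1ccc(NC(=O)c2ccc([N+](=O)[O-])o2)cc1` has hydrogen in place of trifluoromethyl on an aromatic carbon, ortho to an allyloxy group (hydrogen in place of trifluoromethyl on an aromatic carbon). Going by the values given here, the only measured step that bears on this is the same exchange in the opposite direction, on a ring without the allyloxy group (a step that the two limits leave unreadable from compound 1 to compound 2). That step gives no size to carry over, and neither of its two compounds reaches a number. No step beyond the scatter is therefore expected in this assay, and no direction is favoured. The expected change (a number no higher from compound 3 to compound 4 (the limit leaves the size open)) is small, and compound 4 will most likely also report only a limit. For compound 4 the estimated value is 20000 nM and the expected range runs from 8000 nM to 40000 nM in this assay.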

Compound 4, half-maximal effective concentration: > 20000 nM
Compound 4 gave a limit, no number; the forecaster's own chance of this, stated with the estimate: 75%; the middle value lies on the limit itself.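

The steps from compound 1, compound 2 and compound 3 to compound 4 cannot be read in this assay, as each of these compounds gives only a limit: the limit of > 20000 nM in this assay, at which 4 of the 4 values shown sit. The compounds shown leave open whether exchanging hydrogen, trifluoromethyl or allyloxy changes the read-out at all, and in which direction.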